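This account rests on a few compounds, and the source may have more. Where it says the series, first, only, none or still open, it means among the compounds named here.

Measured compounds:
compound 1, `O=C(NCCO)c1c(O)c2ncc(Cc3ccc(F)cc3)cc2[nH]c1=O`, in an ADME assay on the whole organism (plasma, strain CD) for pharmacokinetics, with Rattus norvegicus as the target; a higher number here means faster removal of the compound, a lower number slower removal: "not determined" (no result reported)
compound 2, `COCCNC(=O)c1c(O)c2ncc(Cc3ccc(F)cc3)cc2n(C)c1=O`, in this assay: 11.8 mL/min/kg
compound 3, `C[C@H](CO)NC(=O)c1c(O)c2ncc(Cc3ccc(F)cc3)cc2[nH]c1=O`, in this assay: "not determined" (no result reported)

Compound 1 stands without a number in this assay, and compound 3 likewise has no reported result, so compound 2 alone supplies a clearance figure in this assay, namely 11.8 mL/min/kg. Compound 4, `Cn1c(=O)c(C(=O)NCCO)c(O)c2ncc(Cc3ccc(F)cc3)cc21`, differs from compound 1 by methyl in place of hydrogen on an aromatic nitrogen. Among the compounds with values here, no measured pair shares this change, so its size in this assay cannot be read from the data and no direction is known; with compound 1 itself unmeasured, any step would rest on expectation only. Compound 2 carries the same methyl on the aromatic nitrogen and gives 11.8 mL/min/kg in this assay, which serves as the anchor. Compound 4 is therefore expected to show a clearance near 12 mL/min/kg, within a range of 5 mL/min/kg to 30 mL/min/kg.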

Compound 4, clearance: 3.2 mL/min/kg
Compound 4: the middle estimate sits 3.8-fold (0.57 log units) above what was measured, outside the stated range (below it).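

With the methyl on the aromatic nitrogen kept in place, replacing methyl with hydrogen on the oxygen on a saturated carbon gives a 3.7-fold lower number from compound 2 to compound 4 (0.57 log units; beyond the scatter) in this assay. Within the data shown here, this single pair is the first to show that the end of the amide side chain can shift clearance, while the methyl on the aromatic nitrogen stays constant. Nothing available explains this shift. The step for that methyl itself cannot be read. On these data alone, how an amine or a carboxylic acid in place of the hydroxy group would behave remains open.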